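A few compounds are considered here, and "the series" means these few. Any claim that something is new, unique, unknown or untested is made for them only; others in the source may bear on it.

Compound 1 `CC(C)[C@H](C(=O)Nc1ncc(C(F)(F)F)s1)c1ccc(Cl)cc1`: 95%
Compound 2 `CC(C)(C)[C@H](C(=O)Nc1ncc(F)s1)c1ccc(Cl)cc1`: 92%

Of these two numbers, compound 2 gives the lowest, and its nearest neighbour, compound 1, lies within the usual scatter of it, so the two cannot be told apart on this read-out. Compound 3 `CSc1cnc(NC(=O)[C@H](c2ccc(Cl)cc2)C(C)(C)C)s1` differs from compound 2 by methylsulfanyl in place of fluoro on an aromatic carbon. Going by the values given here, no measured pair shows what this change does, so the expectation rests on the two values alone. In a functional assay on CHO cells for agonist activity at Free fatty acid receptor 2 (Homo sapiens), read by cAMP accumulation (a higher number here means a larger maximal response, a lower number a smaller maximal response), a step no larger than the scatter is expected, in either direction. Compound 3 is therefore estimated at 90%, with a range from 72% to 104%. The expected step is a number 2 percentage points lower from compound 2 to compound 3 (within the scatter).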

Compound 3, largest response reached (reported as efficacy), in percent of the reference or control that the assay uses: 109%
Beside the measured number, compound 3's estimate is 19 percentage points below it; the whole stated range lies below it.
By their numbers in this assay, from the lowest: compounds 2 and 1 (each within the scatter of the next); then compound 3.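

In this assay, methylsulfanyl in place of fluoro on the aromatic carbon next to the ring sulfur gives a number 17 percentage points higher from compound 2 to compound 3 (beyond the scatter). Going by these compounds alone, this is the first single-place comparison, and it shows that the maximal response can shift with the group at this position. Nothing measured here accounts for the step.

This single pair cannot show whether the sulfur or the methyl matters more. Going by these compounds, the response with a methoxy group, an amine or a longer chain such as ethylsulfanyl at this position remains open.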